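This account rests on a few compounds, and the source may have more. Where it says the series, first, only, none or still open, it means among the compounds named here.

In a functional assay on Huh-7 cells (Homo sapiens) for inhibition, read by MTT assay, with a stated time of 48 h (a lower number here means a stronger inhibitor, a higher number a weaker inhibitor), compound 1 `COc1ccc2c(=O)c(/C=C/C(=O)Nc3cccc(C)c3)coc2c1` gives 15500 nM, the highest of the three numbers, though the other two lie within the scatter of it. Compound 2 `COc1ccc2c(=O)c(/C=C/C(=O)NCc3ccccc3)coc2c1` gives 13600 nM and compound 3 `COc1ccc2c(=O)c(/C=C/C(=O)NCc3ccccc3F)coc2c1` gives 8450 nM. Benzyl in place of 3-methylphenyl on the amide-type nitrogen appears as a 1.1-fold lower number from compound 1 to compound 2 (0.06 log units; within the scatter); fluoro in place of hydrogen on an aromatic carbon appears as a 1.6-fold lower number from compound 2 to compound 3 (0.21 log units; within the scatter); taken together these give a 1.8-fold lower number from compound 1 to compound 3 (0.26 log units; within the scatter). Compound 4 `COc1ccc(CNC(=O)/C=C/c2coc3cc(OC)ccc3c2=O)cc1` differs from compound 1 by 4-methoxybenzyl in place of 3-methylphenyl on an amide-type nitrogen. The step from compound 1 to compound 2 bears most directly on this change, and the step from compound 2 to compound 3 shows that a substituent on the benzyl ring moved the number only within the scatter. Compound 4 is therefore expected to show a 1.4-fold lower number from compound 1 to compound 4 (0.15 log units; within the scatter), not beyond the scatter, and is estimated at 11000 nM with a range from 5000 nM to 25000 nM.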

Compound 4, half-maximal inhibitory concentration: 7570 nM
Beside the measured number, compound 4's estimate is 1.5-fold (0.16 log units) above it, within the range that was stated.
By their numbers in this assay, from the lowest: compounds 4, 3, 2 and 1 (each within the scatter of the next, the first and the last beyond it).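

Within the data shown here, on the amide-type nitrogen, 4-methoxybenzyl in place of 3-methylphenyl gives a 2.0-fold lower number from compound 1 to compound 4 (0.31 log units; beyond the scatter) and is the only step to pass the scatter. The two closer comparisons do not pass it: 4-methoxybenzyl in place of benzyl gives a 1.8-fold lower number from compound 2 to compound 4 (0.25 log units; within the scatter) and 4-methoxyphenyl in place of 2-fluorophenyl gives a 1.1-fold lower number from compound 3 to compound 4 (0.05 log units; within the scatter), so compound 4 stands apart only from compound 1. No evidence on why this step passes the scatter is available. As far as these compounds go, whether an amine or a carboxylic acid on the benzyl ring, or a longer chain in place of benzyl, would move the number remains open.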